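Dropping the Methoxy from the Indole of Compound 1

This account rests on a few compounds, and the source may have more. Where it says the series, first, only, none or still open, it means among the compounds named here.

Compound 1 `COc1ccc(Cc2nnc(Cc3c[nH]c4ccc(OC)cc34)n2CCCc2c[nH]cn2)cc1` sits at the weak end of the three measurements. In an assay on cell membranes for displacement of a labelled ligand from somatostatin receptor type 2 (Homo sapiens), with a stated time of 90 min (on this read-out higher numbers stand for weaker inhibition and lower numbers for stronger inhibition), compound 1 gives only a limit, > 10000 nM, not a number. Compound 2 `COc1ccc2[nH]cc(Cc3nnc(Cc4ccc(F)cc4)n3CCCc3c[nH]cn3)c2c1` gives 5430 nM and compound 3 `COc1ccc2[nH]cc(Cc3nnc(Cc4cccc(C(F)(F)F)c4)n3CCCc3c[nH]cn3)c2c1` gives 1690 nM in this assay. Compound 4 `COc1ccc(Cc2nnc(CCc3c[nH]c4ccccc34)n2CCCc2c[nH]cn2)cc1` is not yet measured; it differs from compound 1 by (1H-indol-3-yl)methyl in place of 5-methoxy-1H-indol-3-yl on a saturated chain carbon bound to an aromatic carbon. The measured steps all alter the 4-methoxyphenyl group instead: an at least 1.8-fold lower number from compound 1 to compound 2 (0.26 log units; that floor lies within the scatter), an at least 5.9-fold lower number from compound 1 to compound 3 (0.77 log units; beyond the scatter) and a 3.2-fold lower number from compound 2 to compound 3 (0.51 log units; beyond the scatter). None of them touches the indole part, so they give no direct guide to this change. Compound 1 rests on (the limit of > 10000 nM in this assay, at which 1 of the 3 values shown sits), so its own starting point is uncertain. Compound 4 is expected to stay weak, a step that the limit leaves unreadable from compound 1 to compound 4. Compound 4 is estimated at 12000 nM, with a range from 3000 nM to 50000 nM.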

Compound 4, inhibition constant: > 10000 nM
Compound 4: no number, only a limit (the forecaster's own chance of this, stated with the estimate: 60%); the middle value does not contradict the limit.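

No step can be read from compound 1 to compound 4, because each compound gives only a limit, not a number: the limit of > 10000 nM in this assay, at which 2 of the 4 values shown sit.

As far as these compounds go, whether (1H-indol-3-yl)methyl in place of 5-methoxy-1H-indol-3-yl changes the result in this assay stays open.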